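Oleyl and stearyl amides and ureas as ACAT inhibitors

The source may report more compounds than this note shows. Statements on the series, on what has been measured and on what is new or still open speak of the compounds shown alone.

Measured so far in an assay on microsomes from intestinal mucosa for inhibition of acyl-CoA:cholesterol acyltransferase (Oryctolagus cuniculus); a higher number here means a weaker inhibitor, a lower number a stronger inhibitor:
- compound 1, `CCCCCCCC/C=C\CCCCCCCCNCc1c(OC)cc(OC)cc1OC`: > 100000 nM
- compound 2, `CCCCCCCCCCCCCCCCCCNC(=O)Nc1c(OC)cc(OC)cc1OC`: 900 nM
- compound 3, `CCCCCCCC/C=C\CCCCCCCCNC(=O)c1c(C)cccc1C`: 9800 nM

The value of compound 1 in this assay is a limit of the assay and not a number. Among the two numbers, compound 3 holds the higher one; compound 2 sits lower, and the gap between them lies beyond the scatter.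

Compound 4, `CCCCCCCC/C=C\CCCCCCCCNC(=O)Nc1c(Cl)cc(Cl)cc1Cl`, is not yet measured. It differs from compound 3 in one place: (2,4,6-trichlorophenyl)amino in place of 2,6-dimethylphenyl on a carbonyl carbon. Within the data shown here, no step between measured compounds covers this change. Among the measured compounds shown here, compound 2, the only urea with a number, gives 900 nM in this assay, and compound 4 is also a urea, so a move to a lower number than that of compound 3 is expected, of the size a 9.8-fold lower number from compound 3 to compound 4 (0.99 log units; beyond the scatter). For compound 4 the estimate in this assay is 1000 nM, with a range from 200 nM to 6000 nM.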

Compound 4, half-maximal inhibitory concentration: 1200 nM
For compound 4 the middle estimate is 1.2-fold (0.08 log units) below the measured one; low and high end bracket the measured number.
By their numbers in this assay, from the lowest: compounds 2 and 4 (each within the scatter of the next); then compound 3. At a limit, above all of these: compound 1.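

Among these compounds, on the carbonyl carbon of the oleyl series, (2,4,6-trichlorophenyl)amino in place of 2,6-dimethylphenyl gives in this assay an 8.2-fold lower number from compound 3 to compound 4 (0.91 log units; beyond the scatter), the first step that can be read. The change turns the amide into a urea, brings in one hydrogen-bond donor and replaces the ring substituents all at once, so the step cannot be assigned to any one of these parts. No measurement shown bears on the cause of this step.

From the compounds shown here alone, a urea carrying 2,6-dimethylphenyl on the oleyl chain would separate the linking group from the ring substituents, and that separation remains open. Also open, going by these compounds, is where an amine or a carboxylic acid on the ring, or a longer chain in place of oleyl, would fall in this assay.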